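Allyl amide series: aryl bromo to methoxy, toxicity

This account rests on a few compounds, and the source may have more. Where it says the series, first, only, none or still open, it means among the compounds named here.

In a toxicity assay on the whole organism (strain Icem-CET (SPF Caw)) for cytotoxicity, with Mus musculus as the target (a higher number here means that more compound is needed for the effect, a lower number that less compound is needed), the measured compounds gave:
compound 1 `C#CCNC(=O)/C(C)=C(\C)c1ccc(Br)cc1`: 150 mg/kg
compound 2 `C=CCNC(=O)/C(C)=C(\C)c1ccc(Br)cc1`: 500 mg/kg
compound 3 `C/C(C(=O)NC1CC1)=C(/C)c1ccc(Br)cc1`: 130 mg/kg

Compound 2 stands highest of the three numbers: a 3.3-fold higher number from compound 1 to compound 2 (0.52 log units; beyond the scatter) and a 3.8-fold lower number from compound 2 to compound 3 (0.59 log units; beyond the scatter), both beyond the scatter. a 1.2-fold lower number from compound 1 to compound 3 (0.06 log units; within the scatter) stays within the scatter.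

Compound 4 `C=CCNC(=O)/C(C)=C(\C)c1ccc(OC)cc1` differs from compound 2 in one place: methoxy in place of bromo on an aromatic carbon. None of the three measured steps bears on this change; every one of them alters the group on the amide-type nitrogen and leaves the aromatic ring untouched. The series therefore gives no measured guide for a change on the ring, and no step beyond the scatter is expected in this assay, with a wide range to reflect the missing precedent. Compound 4 is expected at 450 mg/kg (range 180 mg/kg to 1100 mg/kg). The expected step is a 1.1-fold lower number from compound 2 to compound 4 (0.05 log units; within the scatter).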

Compound 4, dose for half-maximal effect: 300 mg/kg
The estimate for compound 4 lay 1.5-fold (0.18 log units) above the measured number, within the range that was stated.
By their numbers in this assay, from the lowest: compounds 3, 1, 4 and 2 (each within the scatter of the next, the first and the last beyond it).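

Among the compounds shown here, the ring position para to a large group is read here for the first time: in this assay methoxy in place of bromo gives a 1.7-fold lower number from compound 2 to compound 4 (0.22 log units; within the scatter), so on the allyl amide this exchange on an aromatic carbon stays within the scatter. The steps beyond the scatter so far all lie on the amide-type nitrogen, and this ring change adds none. No measurement at hand accounts for this step.

Still open, going by these compounds, is whether an amine or a carboxylic acid at this ring carbon would also stay within the scatter, and whether methoxy in place of bromo reads alike on the propargyl and cyclopropyl amides.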